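The source may hold more compounds than are shown below. What is called first, only, known or untested is meant among the compounds shown, and "the series" means these compounds.

Working notes on the sulfonate series in a functional assay on M21 cells (Homo sapiens) for antiproliferative activity, read by sulforhodamine B assay, with a stated time of 48 h; on this read-out higher numbers stand for weaker inhibition and lower numbers for stronger inhibition. Compound 1 `COc1cccc(OS(=O)(=O)c2ccc(N3CCN(C)C3=O)cc2)c1` gives 1600 nM, compound 2 `CCN1CCN(c2ccc(S(=O)(=O)Oc3cccc(OC)c3)cc2)C1=O` gives 7000 nM and compound 3 `CCCCN1CCN(c2ccc(S(=O)(=O)Oc3cccc(OC)c3)cc2)C1=O` gives 30000 nM. Compound 3 carries the highest number of the three: a 19-fold higher number from compound 1 to compound 3 (1.27 log units; beyond the scatter), and a 4.3-fold higher number from compound 2 to compound 3 (0.63 log units; beyond the scatter). The next compound, compound 4 `CCCCN1CCN(c2ccc(S(=O)(=O)Oc3cc(F)cc(F)c3)cc2)C1=O`, differs from compound 3 at the sulfonate oxygen: 3,5-difluorophenyl in place of 3-methoxyphenyl on an oxygen. Among the compounds with values here, none of the measured steps touches this part of the molecule; all three steps (a 4.4-fold higher number from compound 1 to compound 2 (0.64 log units; beyond the scatter), a 19-fold higher number from compound 1 to compound 3 (1.27 log units; beyond the scatter), a 4.3-fold higher number from compound 2 to compound 3 (0.63 log units; beyond the scatter)) change the chain on the ring nitrogen, so no size or direction can be read across for the aryl change. Compound 4 is therefore expected to stay near compound 3, estimated at 25000 nM (range 6000 nM to 100000 nM), with the expected step of a 1.2-fold lower number from compound 3 to compound 4 (0.08 log units; within the scatter).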

Compound 4, half-maximal inhibitory concentration: > 100000 nM
Compound 4: only a limit was reported; the forecaster's own chance of this, stated with the estimate: 20%; middle value at least 4.0-fold (0.60 log units) away from the limit.
By their numbers in this assay, from the lowest: compound 1; then compound 2; then compound 3. At a limit, above all of these: compound 4.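

The aryl group on the oxygen bound to the sulfonyl sulfur proves to be a sensitive position in this assay, which the steps on the ring-nitrogen chain could not show: with 3,5-difluorophenyl in place of 3-methoxyphenyl there is an at least 3.3-fold higher number from compound 3 to compound 4 (0.52 log units; beyond the scatter). For compound 4, > 100000 nM is a limit of the assay, not a number. The step therefore gives a direction and a lower bound on size only.

Open, on these data alone, is how 3-fluorophenyl or 3,5-dimethoxyphenyl would read on that oxygen. Also open, as far as these compounds go, is whether the same aryl change carries over to the methyl-bearing compound 1.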